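Amide nitrogen substituent: 4-methylbenzyl to phenyl

The source may hold more compounds than are shown below. What is called first, only, known or untested is meant among the compounds shown, and "the series" means these compounds.

Going by the values given here, in a functional assay on SW480 cells (Homo sapiens) for cytotoxicity, read by MTT assay, with a stated time of 48 h (a lower number here means a stronger inhibitor, a higher number a weaker inhibitor), compound 2 `COc1cc([C@H]2C[C@]2(CO)C(=O)NCc2ccc(C)cc2)cc(OC)c1OC` stands highest of the two numbers so far at 94000 nM, while compound 1 `COc1cc([C@H]2C[C@]2(CO)C(=O)Nc2ccccc2Cl)cc(OC)c1OC` gives 40200 nM. Compound 3 `COc1cc([C@H]2C[C@]2(CO)C(=O)Nc2ccccc2)cc(OC)c1OC` carries phenyl in place of 4-methylbenzyl on an amide-type nitrogen. Among the compounds with values here, one measured step bears on this change: a 2.3-fold higher number from compound 1 to compound 2 (0.37 log units; beyond the scatter), which is modest but beyond the scatter and put 4-methylbenzyl in place of 2-chlorophenyl at the same nitrogen. Phenyl resembles 2-chlorophenyl more closely than it resembles 4-methylbenzyl, so a step of similar size in the opposite direction is expected in this assay. Within the data shown here, no measured step shows what the chlorine alone contributes, which leaves the range wide. The estimated change is a 1.8-fold lower number from compound 2 to compound 3 (0.26 log units; within the scatter). For compound 3 the expected value is 52000 nM, with an estimated range of 26000 nM to 100000 nM.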

Compound 3, half-maximal inhibitory concentration: > 100000 nM
Compound 3: only a limit was reported; the forecaster's own chance of this, stated with the estimate: 10%; at least 1.9-fold (0.28 log units) between middle value and limit.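

In this assay compound 3 gives > 100000 nM, which is a limit of the assay and not a number, and one of the values in the series sits there: the limit of > 100000 nM in this assay, at which 1 of the 3 values shown sits.
Hydrogen in place of chloro on an aromatic carbon gives an at least 2.4-fold higher number from compound 1 to compound 3 (0.39 log units; beyond the scatter), the first step to isolate the chloro, and it shows that the chloro counts in this assay. Phenyl in place of 4-methylbenzyl on an amide-type nitrogen gives an at least 1.0-fold higher number from compound 2 to compound 3 (0.02 log units; that floor lies within the scatter); that floor lies within the scatter, so the true size of this change cannot be read.

On these data alone, it remains open whether bromo, methoxy or an amine on that aromatic carbon would match the chloro. Also open, as far as these compounds go, is how 2-chlorobenzyl on the amide-type nitrogen would compare with 4-methylbenzyl.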